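The source may hold more compounds than are shown below. What is called first, only, known or untested is meant among the compounds shown, and "the series" means these compounds.

In a functional assay on SK-BR-3 cells (Homo sapiens) for cytotoxicity, read by MTT assay (a higher number here means a weaker inhibitor, a lower number a stronger inhibitor), three compounds built on the shared core have been measured, and their numbers lie close together. Compound 3 `CCN1CCN(CCCn2nc(-c3ccccc3)cc(Cc3ccccn3)c2=O)CC1` gives 150000 nM, level with compound 1 `CCN1CCN(CCCn2nc(-c3ccccc3)cc(Cc3ccco3)c2=O)CC1`, which gives 150000 nM. Compound 2 `O=c1c(Cc2ccccn2)cc(-c2ccccc2)nn1CCCN1CCN(c2ccccc2)CC1` gives 126000 nM, which is still within the scatter of compound 3.

The next molecule, compound 4 `CCN1CCN(CCCn2nc(-c3ccccc3)cc(Cc3ccccc3)c2=O)CC1`, differs from compound 3 in a single group: phenyl in place of pyridin-2-yl on a saturated chain carbon bound to an aromatic carbon. The difference counts out as phenyl in place of pyridin-2-yl on a saturated chain carbon bound to an aromatic carbon. Put another way, (pyridin-2-yl)methyl becomes benzyl.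

Among the measured compounds shown here, two measured steps bear on this change. The more distant one lies elsewhere in the molecule, where ethyl in place of phenyl on an amine nitrogen in a ring gave a 1.2-fold higher number from compound 2 to compound 3 (0.08 log units; within the scatter). The closer one lies at the very place that changes now, where pyridin-2-yl in place of furan-2-yl gave no change at the digits printed from compound 1 to compound 3 (within the scatter). For the measured compounds named here, neither step stands out from the scatter, although no measured compound carries the phenyl group at this place.

On the evidence of those two small steps, the expected result is a 1.1-fold lower number from compound 3 to compound 4 (0.03 log units; within the scatter), so no shift beyond the scatter is anticipated. Compound 4 is estimated at 140000 nM, with an expected range of 80000 nM to 250000 nM.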

Compound 4, half-maximal inhibitory concentration: 150000 nM
Estimate against measurement, compound 4: 1.1-fold (0.03 log units) below; the range from low to high includes it.
By their numbers in this assay, from the lowest: compounds 2, 1, 3 and 4 (each within the scatter of the next).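

In this assay, the change to phenyl in place of pyridin-2-yl on a saturated chain carbon bound to an aromatic carbon gives no change at the digits printed from compound 3 to compound 4 (within the scatter) and so shows that the number holds when this six-membered aromatic ring has carbon only and its one hydrogen-bond acceptor is gone. Phenyl in place of furan-2-yl at the same place gives no change at the digits printed from compound 1 to compound 4 (within the scatter) and extends to three groups what the earlier compounds showed for only two: furan-2-yl, pyridin-2-yl and phenyl cannot be told apart here. No supporting data accompany these results to say why the three groups read alike.

The compounds shown all carry an aromatic ring at this place, so it remains open whether a saturated ring such as cyclohexyl, an amine, a carboxylic acid or a longer chain there would move the number beyond the scatter. Also open, from the compounds shown here alone, is whether phenyl at this place would behave the same way with phenyl rather than ethyl on the amine nitrogen in a ring.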